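A Return from Pyridin-4-yl to a Furan in Compound 4

This account rests on a few compounds, and the source may have more. Where it says the series, first, only, none or still open, it means among the compounds named here.

Three compounds share one core. Compound 1 `Cc1ccc(-c2nc(CNc3ccc(C(=O)NO)cc3)n(-c3ccccc3)n2)cc1` carries a 4-methylphenyl group, compound 2 `O=C(NO)c1ccc(NCc2nc(-c3ccco3)nn2-c2ccccc2)cc1` a furan-2-yl group, and compound 3 `O=C(NO)c1ccc(NCc2nc(-c3ccncc3)nn2-c2ccccc2)cc1` a pyridin-4-yl group. In an assay on Sf9 cells for inhibition of protein deacetylase HDAC6 (Homo sapiens), read by fluorescence, with a stated time of 40 min, tested at 100 nM (a higher number here means more inhibition at the concentration tested (going by the name of the read-out), a lower number less inhibition), compound 1 gives 62.2%, compound 2 gives 59.9%, and compound 3 gives 30.8%. Compound 3 stands lowest of the three in this assay: the step of a number 31.4 percentage points lower from compound 1 to compound 3 (beyond the scatter) and the step of a number 29.1 percentage points lower from compound 2 to compound 3 (beyond the scatter) both lie beyond the scatter, while a number 2.3 percentage points lower from compound 1 to compound 2 (within the scatter) lies within it.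

Compound 4 `Cc1ccc(-c2nc(CNc3ccc(C(=O)NO)cc3)n(-c3ccccc3)n2)o1` has not yet been measured. It differs from compound 3 in one place: 5-methylfuran-2-yl in place of pyridin-4-yl on an aromatic carbon. The step that bears most directly on this change is a number 29.1 percentage points lower from compound 2 to compound 3 (beyond the scatter), the same exchange run backwards apart from the methyl added to the furan; the step of a number 31.4 percentage points lower from compound 1 to compound 3 (beyond the scatter) points the same way. Both steps were large, so compound 4 is expected to regain most of the distance between compound 3 and the other two, and the step is estimated as a number 29.2 percentage points higher from compound 3 to compound 4 (beyond the scatter) in this assay. Compound 4 is therefore expected to give about 60%, with a range from 45% to 72%.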

Compound 4, a percentage reported as inhibition, at one concentration (the size of the read-out at that concentration, not a potency): 60.7%
Beside the measured number, compound 4's estimate is 0.7 percentage points below it; low and high end bracket the measured number.
By their numbers in this assay, from the lowest: compound 3; then compounds 2, 4 and 1 (each within the scatter of the next).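

In this assay the exchange of pyridin-4-yl for 5-methylfuran-2-yl gives a number 29.9 percentage points higher from compound 3 to compound 4 (beyond the scatter) on this aromatic carbon, although the two groups match in their counts of heavy atoms and hydrogen-bond acceptors and each holds one ring hetero atom. The methyl added to the furan-2-yl group leaves the read-out unresolved, with a number 0.8 percentage points higher from compound 2 to compound 4 (within the scatter) in this assay showing that this position accepts that addition without a readable difference. Replacing 4-methylphenyl with 5-methylfuran-2-yl gives a number 1.5 percentage points lower from compound 1 to compound 4 (within the scatter) in this assay so that, among the four groups shown, only the pyridin-4-yl group of compound 3 stands apart, while the other three cannot be told apart.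

On these data alone, it remains open whether a phenyl ring bearing an amine or a carboxylic acid, or a pyridin-3-yl ring, would fall with compound 3 or with the other three at this position, and a read-out at one concentration gives no potency for any of the four. Nothing available here accounts for the gap between pyridin-4-yl and the other groups.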